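The compounds below may be only part of what the source reports. "The series", "measured", "known", "first", "only" and "open" are said of these compounds alone.

Measured so far in a functional assay on MDA-MB-231 cells (Homo sapiens) for cytotoxicity, read by MTT assay, with a stated time of 72 h; on this read-out higher numbers stand for weaker inhibition and lower numbers for stronger inhibition:
compound 1 `CN(C)CCCCn1c2c(c3ccccc31)C(=O)c1c[n+]([O-])c3ccccc3c1C2=O` gives 350 nM
compound 2 `CN1CCN(CCCCn2c3c(c4ccccc42)C(=O)c2c[n+]([O-])c4ccccc4c2C3=O)CC1` gives 110 nM
compound 3 `O=C1c2c[n+]([O-])c3ccccc3c2C(=O)c2c1c1ccccc1n2CCCCn1ccnc1` gives 210 nM

Compound 3 has the second highest of these three numbers, but its steps from the other two, a 1.7-fold lower number from compound 1 to compound 3 (0.22 log units; within the scatter) and a 1.9-fold higher number from compound 2 to compound 3 (0.28 log units; within the scatter), both lie within the scatter, so no order between compound 3 and either of them is established. Compound 4 `O=C1c2c[n+]([O-])c3ccccc3c2C(=O)c2c1c1ccccc1n2CCN1CCCCC1` differs from compound 3 as follows: piperidin-1-yl in place of 2-(1H-imidazol-1-yl)ethyl on a saturated chain carbon, two bonds along the chain from an aromatic nitrogen. For the measured compounds named here, no measured step shows this exact change. Going by the values given here, the nearest comparisons are the exchanges of the attached group among the measured compounds: a 3.2-fold lower number from compound 1 to compound 2 (0.50 log units; beyond the scatter) was the only step beyond the scatter, and the two steps to compound 3 were small. A small step in this assay is therefore expected, a 1.2-fold lower number from compound 3 to compound 4 (0.09 log units; within the scatter). Compound 4 is estimated at 170 nM, within a range from 60 nM to 450 nM.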

Compound 4, half-maximal inhibitory concentration: 1050 nM
Compound 4: middle estimate off by 6.2-fold (0.79 log units), on the low side, and the stated range ends below it.
By their numbers in this assay, from the lowest: compounds 2, 3 and 1 (each within the scatter of the next, the first and the last beyond it); then compound 4.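

In this assay, for the compounds shown here, this change is the first to raise the number beyond the scatter, with a 5.0-fold higher number from compound 3 to compound 4 (0.70 log units; beyond the scatter) and a 9.5-fold higher number from compound 2 to compound 4 (0.98 log units; beyond the scatter) and also a 3.0-fold higher number from compound 1 to compound 4 (0.48 log units; beyond the scatter), so compound 4 is the weakest of the four. Unlike the earlier exchanges, it alters the chain and its end group together, as 4-(1H-imidazol-1-yl)butyl gives way to 2-(piperidin-1-yl)ethyl. No available evidence explains this rise. The compounds shown leave open whether the shorter chain or the piperidine ring accounts for it. A 4-(piperidin-1-yl)butyl chain would separate the two.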